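The source may hold more compounds than are shown below. What is called first, only, known or untested is meant among the compounds shown, and "the series" means these compounds.

In a functional assay on PC-3 cells (Homo sapiens) for cytotoxicity, read by MTT assay, with a stated time of 72 h (a lower number here means a stronger inhibitor, a higher number a weaker inhibitor), compound 1 `COc1cc2ncnc(Nc3ccc(F)c(Cl)c3)c2cc1NC(=O)/C=C/c1ccccc1[N+](=O)[O-]` gives 14300 nM and compound 2 `O=C(/C=C/c1cc(Br)c(O)c(Br)c1)Nc1cc2c(Nc3ccc(F)c(Cl)c3)ncnc2cc1O[C@H]1CCOC1` gives 25500 nM as its value, so the two stand level within the usual scatter. Compound 3 `COc1cc(/C=C/C(=O)Nc2cc3c(Nc4ccc(F)c(Cl)c4)ncnc3cc2OC)cc(OC)c1` has 3,5-dimethoxyphenyl in place of 2-nitrophenyl on a double-bonded chain carbon bound to a double-bonded chain carbon and remains unmeasured. Going by the values given here, no measured pair isolates such a change. Compound 2 carries a differently substituted phenyl and gives 25500 nM within the scatter of compound 1. The estimated step of a 1.1-fold higher number from compound 1 to compound 3 (0.05 log units; within the scatter) is therefore expected to stay within the scatter, with neither direction favoured. For compound 3 the estimated value is 16000 nM with an expected range from 6000 nM to 40000 nM in this read-out.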

Compound 3, half-maximal inhibitory concentration: "not active" (no number reported)
The entry for compound 3 holds no number; there is nothing to compare the estimate with.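

Going by these compounds alone, compound 3 is recorded as not active in this assay with no number, so no step from compound 1 to compound 3 can be read. No evidence bears on this result. Going by these compounds, what 3,5-dimethoxyphenyl in place of 2-nitrophenyl does to the value stays open.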